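Fluoro in place of amino: what compound 3 may show

The compounds below may be only part of what the source reports. "The series", "measured", "known", "first", "only" and "open" are said of these compounds alone.

Compound 1 `COc1ccc(/C=C/c2cc(OC)cc(OC)c2/C=C/C(=O)c2cccc(OC)c2)cc1`: 6.1 ug/mL
Compound 2 `COc1ccc(/C=C/c2cc(OC)cc(OC)c2/C=C/C(=O)c2ccc(N)cc2)cc1`: 3.8 ug/mL

For the measured compounds named here, in a functional assay on A549 cells (Homo sapiens) for antiproliferative activity, read by MTT assay, with a stated time of 48 h (a lower number here means a stronger inhibitor, a higher number a weaker inhibitor), compound 2 lies within the scatter of compound 1, its only measured neighbour. Compound 3 `COc1ccc(/C=C/c2cc(OC)cc(OC)c2/C=C/C(=O)c2ccc(F)cc2)cc1` carries fluoro in place of amino on an aromatic carbon, para to a large group: fluoro in place of amino on an aromatic carbon. Going by the values given here, no measured step covers this exchange, and the sole guide, which involves a different pair of groups, is a 1.6-fold lower number from compound 1 to compound 2 (0.21 log units; within the scatter). A change beyond the scatter is therefore not expected, and the estimated step is a 1.3-fold higher number from compound 2 to compound 3 (0.12 log units; within the scatter). For compound 3 the expected value is 5 ug/mL, with an estimated range of 2 ug/mL to 12 ug/mL.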

Compound 3, half-maximal inhibitory concentration: 6.6 ug/mL
For compound 3 the middle estimate is 1.3-fold (0.12 log units) below the measured one; the measured number falls inside the stated range.
By their numbers in this assay, from the lowest: compounds 2, 1 and 3 (each within the scatter of the next).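

In this assay, the exchange of fluoro for amino on an aromatic carbon, para to a large group, gives a 1.7-fold higher number from compound 2 to compound 3 (0.24 log units; within the scatter) and so stays within the scatter, although the hydrogen-bond donor and acceptor counted for amino leave. Likewise, the exchange of the group on the carbonyl carbon gives a 1.1-fold higher number from compound 1 to compound 3 (0.03 log units; within the scatter) and does not separate these compounds. No evidence is available to explain these results. The compounds shown leave open whether a carboxylic acid, a dimethylamino group or a chloro group at this place would give a step beyond the scatter.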